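This account rests on a few compounds, and the source may have more. Where it says the series, first, only, none or still open, it means among the compounds named here.

Among the compounds with values here, compound 2 `CC1=CC[C@H]2[C@H](CC[C@]2(C)O)C(C)(C)[C@@H]1CC[C@H]1[C@]2(C)CC[C@H](OC(=O)c3ccc([N+](=O)[O-])cc3)C(C)(C)O[C@H]2CC[C@@]1(C)O` stands lowest of the two numbers so far in a functional assay on MDA-MB-231 cells (Homo sapiens) for antiproliferative activity, read by MTT assay, with a stated time of 72 h (a lower number here means a stronger inhibitor, a higher number a weaker inhibitor), where compound 2 gives 8900 nM; compound 1 `CC1=CC[C@H]2[C@H](CC[C@]2(C)O)C(C)(C)[C@@H]1CC[C@H]1[C@]2(C)CC[C@H](OC(=O)CCC(=O)O)C(C)(C)O[C@H]2CC[C@@]1(C)O` gives 27900 nM, and the single measured step, a 3.1-fold lower number from compound 1 to compound 2 (0.50 log units; beyond the scatter), exchanges a 2-carboxyethyl chain for an aryl group. Compound 3 `CC1=CC[C@H]2[C@H](CC[C@]2(C)O)C(C)(C)[C@@H]1CC[C@H]1[C@]2(C)CC[C@H](OC(=O)c3ccccc3C(F)(F)F)C(C)(C)O[C@H]2CC[C@@]1(C)O` carries the change (2-(trifluoromethyl)phenyl in place of 4-nitrophenyl on a carbonyl carbon). Within the data shown here, no measured step compares one aryl group with another, so the step from compound 1 to compound 2 bears on this one only loosely. For compound 3 the step of a 1.0-fold higher number from compound 2 to compound 3 (0.00 log units; within the scatter) is expected, no more than the scatter. Compound 3 is estimated at 9000 nM, within 3000 nM to 27000 nM.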

Compound 3, half-maximal inhibitory concentration: 31500 nM
Estimate against measurement, compound 3: 3.5-fold (0.54 log units) below, outside the stated range (above it).
By their numbers in this assay, from the lowest: compound 2; then compounds 1 and 3 (each within the scatter of the next).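

In this assay the aryl group on this carbonyl carbon matters and not just its presence: 2-(trifluoromethyl)phenyl in place of 4-nitrophenyl gives a 3.5-fold higher number from compound 2 to compound 3 (0.55 log units; beyond the scatter) and removes the gain seen with compound 2. The other step, a 1.1-fold higher number from compound 1 to compound 3 (0.05 log units; within the scatter), leaves the 2-(trifluoromethyl)phenyl ester level with the 2-carboxyethyl ester, so an aryl group alone does not give the lower number. No available measurement accounts for this difference. Still open, as far as these compounds go, is whether an unsubstituted phenyl or a 4-aminophenyl group here would stand with compound 2 or with compound 3.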